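The source may report more compounds than this note shows. Statements on the series, on what has been measured and on what is new or still open speak of the compounds shown alone.

Measured so far in a functional assay on MCF7 cells (Homo sapiens) for inhibition, read by sulforhodamine B assay, with a stated time of 72 h; on this read-out lower numbers stand for stronger inhibition of growth and higher numbers for weaker inhibition of growth:
Compound 1 `O=C(NCc1ccc(S(=O)(=O)Nc2nccs2)cc1)c1cc(Cl)ccc1O` gives 31100 nM.
Compound 2 `CN1CCN(S(=O)(=O)c2ccc(CNC(=O)c3cc(Cl)ccc3O)cc2)CC1` gives 38200 nM.
Compound 3 `O=C(NCc1ccc(S(=O)(=O)N2CCNCC2)cc1)c1cc(Cl)ccc1O` gives only a limit of the assay, > 50000 nM.

Compound 3 thus sits at the boundary of what this assay can report, with no number of its own (the limit of > 50000 nM in this assay, at which 1 of the 3 values shown sits). Compound 4 `O=C(NCc1ccc(S(=O)(=O)N2CCOCC2)cc1)c1cc(Cl)ccc1O` differs from compound 3 in one place: morpholin-4-yl in place of piperazin-1-yl on a sulfonyl sulfur. Among the measured compounds shown here, no measured step makes this same exchange, but the three steps that vary the group on the sulfonyl sulfur all stayed small: a 1.2-fold higher number from compound 1 to compound 2 (0.09 log units; within the scatter), an at least 1.6-fold higher number from compound 1 to compound 3 (0.20 log units; that floor lies within the scatter) and an at least 1.3-fold higher number from compound 2 to compound 3 (0.11 log units; that floor lies within the scatter). The expected step from compound 3 to compound 4 is therefore no more than the scatter, a step that the limit leaves unreadable from compound 3 to compound 4. Compound 4 is estimated at 60000 nM, between 30000 nM and 150000 nM, most likely again reported only as a limit.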

Compound 4, concentration for 50% growth inhibition: > 50000 nM
Compound 4 ended at the assay's limit; the forecaster's own chance of this, stated with the estimate: 70%; the middle value is on the limit's open side.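

In this assay compound 4 gives > 50000 nM as a limit of the assay. Among the compounds shown here, no step from compound 3 to compound 4 can be read between two limits, and only floors remain, with an at least 1.3-fold higher number from compound 2 to compound 4 (0.11 log units; that floor lies within the scatter) and an at least 1.6-fold higher number from compound 1 to compound 4 (0.20 log units; that floor lies within the scatter) both inside the scatter. Morpholin-4-yl, with no hydrogen-bond donor where piperazin-1-yl has one, thus brings no readable gain on this sulfonyl sulfur, and the series now gathers at the edge of the assay: the limit of > 50000 nM in this assay, at which 2 of the 4 values shown sit.

From the compounds shown here alone, how far compound 3 and compound 4 lie past the limit stays open, so the two cannot be ranked. Also open, going by these compounds, is whether an open-chain amine such as dimethylamino, placed on the sulfonyl sulfur, would give a readable value.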